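The source may report more compounds than this note shows. Statements on the series, on what has been measured and on what is new or still open speak of the compounds shown alone.

Compound 3 `Cc1ccc2c(NCc3ccc(NC(=O)C4CCN(Cc5ccccc5)CC4)cc3)nc(N3CCN[C@@H](C)C3)nc2c1` is one of three measured members of this series, and in a functional assay on SV5A8 cells (Homo sapiens) for cytotoxicity (a lower number here means a stronger inhibitor, a higher number a weaker inhibitor), it is reported only as a limit, giving > 8860 nM. Compound 1 `Cc1ccc2c(NCc3ccc(NC(=O)C4CCN(Cc5cccc(F)c5)CC4)cc3)nc(N(C)C)nc2c1` is likewise reported only as a limit in this assay, with > 4170 nM. Compound 2 `Cc1ccc2c(NCc3ccc(NC(=O)C4CCN(Cc5ncc[nH]5)CC4)cc3)nc(N(C)C)nc2c1` gives > 20000 nM, again a limit. For the measured compounds named here, the single step between measured compounds that differ in one place, a step that the two limits leave unreadable from compound 1 to compound 2, cannot be read in size or direction, since both ends are limits; the three values sit at the limit of > 4170 nM in this assay, at which 1 of the 3 values shown sits, the limit of > 8860 nM in this assay, at which 1 of the 3 values shown sits, and (the limit of > 20000 nM in this assay, at which 1 of the 3 values shown sits). Compound 4 `CCNc1nc(NCc2ccc(NC(=O)C3CCN(Cc4ccccc4)CC3)cc2)c2ccc(C)cc2n1` differs from compound 3 by ethylamino in place of 3-methylpiperazin-1-yl on an aromatic carbon. Going by the values given here, no measured step bears directly on this change, and every measured value in this assay is a limit, so no size of step can be anticipated beyond a weak expectation that compound 4 also remains at or beyond the limit. Compound 4 is therefore estimated at 15000 nM, within 4000 nM to 60000 nM, an expected step that the limit leaves unreadable from compound 3 to compound 4.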

Compound 4, half-maximal inhibitory concentration: > 2140 nM
Compound 4: a limit, no number (the forecaster's own chance of this, stated with the estimate: 80%); the middle value lies beyond the limit too.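

Compound 3 and compound 4 are both reported only as limits, so the change from 3-methylpiperazin-1-yl to ethylamino gives no readable step. The compounds shown leave open whether any of these changes alters the read-out at all: every value is a limit.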